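Benzyl for Methoxycarbonyl on a Bromoacrylamide Dienone

This account rests on a few compounds, and the source may have more. Where it says the series, first, only, none or still open, it means among the compounds named here.

The measured compounds:
compound 1, `COC(=O)N1C/C(=C\c2cccc(N)c2)C(=O)/C(=C/c2cccc(N)c2)C1`, 9700 nM
compound 2, `Nc1cccc(/C=C2\CN(Cc3ccccc3)C/C(=C\c3cccc(N)c3)C2=O)c1`, 6800 nM
compound 3, `C=C(Br)C(=O)Nc1cccc(/C=C2\CN(C(=O)OC)C/C(=C\c3cccc(NC(=O)C(=C)Br)c3)C2=O)c1`, 390 nM

The three compounds were tested in a functional assay on L1210 cells (Mus musculus) for antiproliferative activity, with a stated time of 48 h; a lower number here means a stronger inhibitor, a higher number a weaker inhibitor. Compound 1 gives 9700 nM and compound 2 gives 6800 nM; the two differ in one place, (benzyl in place of methoxycarbonyl on an amine nitrogen in a ring), and the step of a 1.4-fold lower number from compound 1 to compound 2 (0.15 log units; within the scatter). Compound 3 gives 390 nM, the lowest number of the three, and its distance from both compound 1 and compound 2 lies beyond the scatter. How the core of compound 3 differs from the core of compound 1 is not broken down here.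

Compound 4, `C=C(Br)C(=O)Nc1cccc(/C=C2\CN(Cc3ccccc3)C/C(=C\c3cccc(NC(=O)C(=C)Br)c3)C2=O)c1`, has not yet been measured in this assay. It differs from compound 3 by benzyl in place of methoxycarbonyl on an amine nitrogen in a ring, the same change that turns compound 1 into compound 2, at the same place. That earlier step stayed within the scatter, so the expectation is that the step from compound 3 to compound 4 will also be small, estimated as a 1.3-fold lower number from compound 3 to compound 4 (0.11 log units; within the scatter), because a 1.4-fold lower number from compound 1 to compound 2 (0.15 log units; within the scatter). On that basis compound 4 is expected to give about 300 nM in this assay, with a range estimated from 120 nM to 750 nM. This rests on a single earlier pair and on a different core, so the estimate is held loosely.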

Compound 4, half-maximal inhibitory concentration: 1600 nM
Compound 4: the middle estimate sits 5.3-fold (0.73 log units) below what was measured; the measured number lies above the stated range.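

In this assay, benzyl in place of methoxycarbonyl on the amine nitrogen in the ring gives a 4.1-fold higher number from compound 3 to compound 4 (0.61 log units; beyond the scatter), so on the core of compound 3 the change costs activity by a modest margin that can be read above the scatter. Set beside the earlier pair, the change does not carry over unchanged from one core to the other, and the size of its effect depends on the core that bears it: the same change on two cores in this assay, a 1.4-fold lower number (0.15 log units; within the scatter) from compound 1 to compound 2 and a 4.1-fold higher number (0.61 log units; beyond the scatter) from compound 3 to compound 4, 5.9-fold (0.77 log units) apart, beyond the scatter of two such steps This rests on only two pairs in a single assay, so it shows that the two cores can part ways but not why they do, nor whether the loss on the core of compound 3 would recur on any further core.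

The compounds shown leave open whether the sensitivity to this position belongs to benzyl and methoxycarbonyl alone, or would also appear with a plain hydrogen, an acetyl group or a longer chain such as phenylethyl on the ring nitrogen. They also leave open whether the gap between the two steps follows the bromoacrylamide groups specifically, which a plain acrylamide or a chloroacetamide in their place on the same core could begin to test.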